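The source may report more compounds than this note shows. Statements on the series, on what has been measured and on what is new or still open speak of the compounds shown alone.

Measured so far in a functional assay on HL-60 cells (Homo sapiens) for inhibition, read by MTT assay, with a stated time of 72 h; a lower number here means a stronger inhibitor, a higher number a weaker inhibitor:

- compound 1 `Cc1ccc(N2CCN(C(=O)c3oc(C)nc3-c3ccccc3)CC2)c(C)c1` gives 101 nM
- compound 2 `Cc1nc(-c2ccccc2)c(C(=O)N2CCN(c3ccccc3Cl)CC2)o1` gives 124 nM
- compound 3 `Cc1cc(C)cc(N2CCN(C(=O)c3oc(C)nc3-c3ccccc3)CC2)c1` gives 34.5 nM

Compound 3 has the lowest number of the three, and both of its gaps lie beyond the scatter: a 2.9-fold lower number from compound 1 to compound 3 (0.47 log units; beyond the scatter) and a 3.6-fold lower number from compound 2 to compound 3 (0.56 log units; beyond the scatter). The remaining pair shows no real difference, with a 1.2-fold higher number from compound 1 to compound 2 (0.09 log units; within the scatter).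

The next compound is compound 4 `Cc1nc(-c2ccccc2)c(C(=O)N2CCN(c3cccc(C(F)(F)F)c3)CC2)o1`, which keeps the shared core of compound 3 and changes only the aryl group: 3-(trifluoromethyl)phenyl in place of 3,5-dimethylphenyl on an amine nitrogen in a ring. Thus 3-(trifluoromethyl)phenyl stands in place of 3,5-dimethylphenyl on an amine nitrogen in a ring.

All three measured steps change the group at this same place, so all bear on the question, although none of them involves a trifluoromethyl group. Both compounds that lack the 3,5-dimethylphenyl group have higher numbers, with compound 1 at 101 nM and compound 2 at 124 nM. A modest step toward a higher number is therefore expected in this assay, of about the size seen in those two steps, though it may stay close to the scatter. The expected step is a 2.0-fold higher number from compound 3 to compound 4 (0.31 log units; beyond the scatter). The estimated value for compound 4 is 70 nM, with an expected range of 25 nM to 190 nM.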

Compound 4, half-maximal inhibitory concentration: 153 nM
The estimate for compound 4 lay 2.2-fold (0.34 log units) below the measured number; the range from low to high includes it.
By their numbers in this assay, from the lowest: compound 3; then compounds 1, 2 and 4 (each within the scatter of the next).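

In this assay, the low number of compound 3 does not carry over to the 3-(trifluoromethyl)phenyl group, with a 4.4-fold higher number from compound 3 to compound 4 (0.65 log units; beyond the scatter), so a trifluoromethyl group in the 3 position of the name does not stand in for the two methyl groups of 3,5-dimethylphenyl at this amine nitrogen in a ring. The new group also shows no real separation from the two earlier aryl groups, with a 1.2-fold higher number from compound 2 to compound 4 (0.09 log units; within the scatter) and a 1.5-fold higher number from compound 1 to compound 4 (0.18 log units; within the scatter), which leaves compounds 1, 2 and 4 together within the scatter and compound 3 alone as the strongest of the four, its steps to all the others being beyond the scatter. No measurement shown here accounts for this step.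

The step from compound 3 to compound 4 changes both the kind of group and the number of groups on the aryl ring, so the compounds shown cannot say which of the two goes with the higher number. From the compounds shown here alone, a 3-methylphenyl or a 3,5-bis(trifluoromethyl)phenyl group at the same nitrogen would separate the two, and whether a 3,5-dichlorophenyl group matches 3,5-dimethylphenyl also stays open.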